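A few compounds are considered here, and "the series" means these few. Any claim that something is new, unique, unknown or untested is made for them only; others in the source may bear on it.

Measured compounds:
- compound 1 `Cn1nccc1C(=O)NCc1ccc(CNS(=O)(=O)c2ccc3c(c2)CCO3)cc1`; in an assay on cells for displacement of a labelled ligand from C-X-C chemokine receptor type 4 (Homo sapiens), read by fluorescence and microscopy, with stated times of 10 min and 30 min (on this read-out lower numbers stand for an effect already at smaller amounts and higher numbers for an effect only at larger amounts of compound), compound 1 gives 1000 nM.
- compound 2 `O=C(NCc1ccc(CNS(=O)(=O)c2ccc3c(c2)CCO3)cc1)c1cc2ccccn2n1`; compound 2 gives 1 nM.
- compound 3 `O=C(NCc1ccc(CNS(=O)(=O)c2ccc3c(c2)CCO3)cc1)c1cccnc1`; compound 3 gives 1000 nM.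

Compound 3 stands level with compound 1 at the digits shown, and together they hold the highest numbers of the three; compound 2 lies far below both. The steps are no change at the digits printed from compound 1 to compound 3 (within the scatter), a 1000-fold lower number from compound 1 to compound 2 (3.00 log units; beyond the scatter) and a 1000-fold higher number from compound 2 to compound 3 (3.00 log units; beyond the scatter).

Compound 4 `O=C(NCc1ccc(CNS(=O)(=O)c2ccc3c(c2)CCO3)cc1)c1scc2c1OCCO2` differs from compound 3 in one place: a group of 9 heavy atoms (6 carbon, 2 oxygen, 1 sulfur; one five-membered aromatic ring with 1 hetero atom, one six-membered non-aromatic ring with 2 hetero atoms) in place of a group of 6 heavy atoms (5 carbon, 1 nitrogen; one six-membered aromatic ring with 1 hetero atom), on a carbonyl carbon. The group enters on a carbonyl carbon whose other neighbour is an amide-type nitrogen.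

For the measured compounds named here, two measured steps bear on this. The exchange of one single-ring group for another, no change at the digits printed from compound 1 to compound 3 (within the scatter), left the number unchanged. The exchange of a single ring for a two-ring group of 9 heavy atoms, in reverse direction a 1000-fold higher number from compound 2 to compound 3 (3.00 log units; beyond the scatter), was large. The incoming group of compound 4 matches the group of compound 2 in heavy-atom count and in carrying two rings, but one of its rings is non-aromatic and it carries oxygen and sulfur rather than nitrogen, so the large gain seen for compound 2 cannot simply be carried over. For compound 4 the expected step is smaller than that, namely an expected 10-fold lower number from compound 3 to compound 4 (1.00 log units; beyond the scatter). Compound 4 is therefore estimated at 100 nM, within 10 nM to 1000 nM.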

Compound 4, effective concentration (reported as EC, without a stated level of effect): 10 nM
Beside the measured number, compound 4's estimate is 10-fold (1.00 log units) above it, and the stated range covers the measured number.
By their numbers in this assay, from the lowest: compound 2; then compound 4; then compounds 1 and 3 (each within the scatter of the next).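

In this assay, the large gain on the carbonyl carbon is no longer confined to the group of compound 2: the group with one five-membered aromatic ring with 1 hetero atom and one six-membered non-aromatic ring with 2 hetero atoms gives a 100-fold lower number from compound 3 to compound 4 (2.00 log units; beyond the scatter) and a 100-fold lower number from compound 1 to compound 4 (2.00 log units; beyond the scatter). This gain comes with oxygen and sulfur in the incoming group, so the nitrogen atoms of the group in compound 2 are not required for a step of this kind within these compounds. The two groups of 9 heavy atoms are still not interchangeable, as a 10-fold higher number from compound 2 to compound 4 (1.00 log units; beyond the scatter) shows that equal heavy-atom and ring counts do not fix the number at this position; no measurement at hand accounts for any of these steps.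

Open, from the compounds shown here alone, is whether the gain follows the second ring or simply the larger group, a question that a single ring of comparable size, such as a phenyl carrying a butoxy chain, would address. Also open, going by these compounds, is how an amine or a carboxylic acid on the two-ring group would read in this assay.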